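The compounds below may be only part of what the source reports. "The series", "measured", "known", "first", "only" and "open" are said of these compounds alone.

The three measured compounds share the core of compound 1, `CC1CCCCN1C(=S)SCc1ccc(C(=O)Nc2ccccc2N)cc1`, which in a functional assay on HeLa cells (Homo sapiens) for antiproliferative activity, read by CCK-8 assay, with a stated time of 72 h, tested at 2 uM (a higher number here means a stronger effect of the compound at the concentration tested, a lower number a weaker effect), gives 45.5%. Compound 2, `COc1ccc(N2CCN(C(=S)SCc3ccc(C(=O)Nc4ccccc4N)cc3)CC2)cc1`, gives 39.4% in this assay. Compound 3, `Nc1ccccc1NC(=O)c1ccc(CSC(=S)N2CCc3cc(Cl)ccc32)cc1`, gives 40.1% in this assay. On the numbers shown, compound 2 does not separate from either of the other two: its number sits within the scatter of the number for compound 3 and within the scatter of the number for compound 1.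

Within the data shown here, the only step between measured compounds is a number 5.4 percentage points lower from compound 1 to compound 3 (within the scatter), a change on the thiocarbonyl carbon rather than on the aryl group of a ring nitrogen, so it speaks to the general tolerance of the amine part but not to the change at hand.

Compound 4, `Nc1ccccc1NC(=O)c1ccc(CSC(=S)N2CCN(c3cccnc3)CC2)cc1`, differs from compound 2 by pyridin-3-yl in place of 4-methoxyphenyl on an amine nitrogen in a ring. Among the measured compounds shown here, no measured pair shows this exchange, and the one measured step elsewhere in the amine part stayed within the scatter, so a step in this assay beyond the scatter is not expected in either direction. The estimated step is a number 0.6 percentage points higher from compound 2 to compound 4 (within the scatter). Compound 4 is therefore expected to give 40%, with a range from 28% to 52%.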

Compound 4, a percentage reported as inhibition, at one concentration (the size of the read-out at that concentration, not a potency): 66.2%
For compound 4 the middle estimate is 26.2 percentage points below the measured one, outside the stated range (above it).
By their numbers in this assay, from the lowest: compounds 2, 3 and 1 (each within the scatter of the next); then compound 4.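

The exchange of 4-methoxyphenyl for pyridin-3-yl on an amine nitrogen in a ring gives, in this assay, a number 26.8 percentage points higher from compound 2 to compound 4 (beyond the scatter), and this is the only step among the compounds shown that lies beyond the scatter. It shows that the group on this nitrogen can move the read-out substantially, which the earlier step on the thiocarbonyl carbon, a change elsewhere in the amine part, could not reveal. Nothing shown bears on why this exchange raises the number.

The exchange removes the methoxy group and places a nitrogen in the aromatic ring at once, so this single pair cannot separate the two changes, and a plain phenyl group or a pyridin-4-yl group at the same place would be needed to tell whether the methoxy group, the ring nitrogen or that nitrogen's location accounts for the step. Since the read-out is the size of the effect at one concentration, it also leaves open how far the step would carry over to potency.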